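The source may report more compounds than this note shows. Statements on the series, on what has been measured and on what is new or still open speak of the compounds shown alone.

Three compounds sharing the same kind of acid-bearing core were tested in a functional assay on V79 cells (Cricetulus griseus) for cytotoxicity, read by colony formation; a higher number here means a weaker inhibitor, a lower number a stronger inhibitor. Compound 2 `CCn1cc(C(=O)O)c(=O)c2cc(F)c(N3CCC(N)C3)c(F)c21` carries an amino group on a saturated ring carbon, and in this assay compound 2 gives 300 ug/mL. Compound 1 `CCNCC1CCN(c2c(F)cc3c(=O)c(C(=O)O)cn(CC)c3c2F)C1` differs from it in one place: (ethylamino)methyl in place of amino on a saturated ring carbon. In this assay compound 1 gives 160 ug/mL, and the step of a 1.9-fold lower number from compound 2 to compound 1 (0.27 log units; within the scatter) is small. Compound 3 `NC1CCN(c2c(F)c(F)c3c(=O)c(C(=O)O)cn(C4CC4)c3c2F)C1` has a different core; the difference between the two cores is not broken down here. In this assay compound 3 gives 100 ug/mL; its gap to compound 1 is within the scatter, while its gap to compound 2 lies beyond it. Compound 4 `CCNCC1CCN(c2c(F)c(F)c3c(=O)c(C(=O)O)cn(C4CC4)c3c2F)C1` has not yet been measured. It differs from compound 3 by (ethylamino)methyl in place of amino on a saturated ring carbon, the same change that turns compound 2 into compound 1, at the same place. The expected step of a 1.4-fold lower number from compound 3 to compound 4 (0.15 log units; within the scatter) rests on the earlier step of a 1.9-fold lower number from compound 2 to compound 1 (0.27 log units; within the scatter) in this assay, which changed little. Compound 4 is estimated at 70 ug/mL, with a likely range from 35 ug/mL to 140 ug/mL.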

Compound 4, half-maximal inhibitory concentration: 46 ug/mL
Compound 4: middle estimate off by 1.5-fold (0.18 log units), on the high side; low and high end bracket the measured number.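

Putting (ethylamino)methyl in place of amino on the saturated ring carbon of the core of compound 3 gives, in this assay, a 2.2-fold lower number from compound 3 to compound 4 (0.34 log units; beyond the scatter), a modest step in the direction of a stronger inhibitor. Set beside the earlier case, the change gives much the same step on both cores: the same change on two cores in this assay, a 1.9-fold lower number (0.27 log units; within the scatter) from compound 2 to compound 1 and a 2.2-fold lower number (0.34 log units; beyond the scatter) from compound 3 to compound 4, 1.2-fold (0.06 log units) apart, within the scatter of two such steps. Going by these compounds alone, this is only one pair on each of two cores, so it does not show that the step would hold on a further core, and it offers no explanation of how the change acts.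

As far as these compounds go, how a plain aminomethyl group or a longer (propylamino)methyl group on the same ring carbon would read in this assay remains open, and with it the question of which part of the change goes with the step. Also open, from the compounds shown here alone, is whether a carboxylic ester in place of the carboxylic acid would leave this step intact.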